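Methylsulfamoyl in place of (2-methoxyethyl)carbamoyl in the series

The source may hold more compounds than are shown below. What is called first, only, known or untested is meant among the compounds shown, and "the series" means these compounds.

Compound 1 `COCCNC(=O)[C@H]1CC[C@H](Nc2ncc3c(Br)nn(-c4ccc5ncccc5c4)c3n2)C1` and compound 2 `COCCNC(=O)[C@@H]1CC[C@@H](Nc2ncc3c(Br)nn(-c4ccc5ncccc5c4)c3n2)C1` share every atom and bond and differ only in configuration. In an assay on isolated protein for inhibition of eIF-2-alpha kinase GCN2 (Homo sapiens) (a lower number here means a stronger inhibitor, a higher number a weaker inhibitor), compound 1 gives 144 nM, while compound 2 gives 5 nM. The step of a 29-fold lower number from compound 1 to compound 2 (1.46 log units; beyond the scatter) rests on (the fact that compounds 1 and 2 differ only in the configuration as drawn). Compound 2 thus stands with the lowest number of the two measured, and its nearest neighbour in this assay is compound 1.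

Compound 3 `CNS(=O)(=O)[C@@H]1CC[C@@H](Nc2ncc3c(Br)nn(-c4ccc5ncccc5c4)c3n2)C1` keeps the configuration of compound 2 and differs from it in methylsulfamoyl in place of (2-methoxyethyl)carbamoyl on a saturated ring carbon. Among the measured compounds shown here, the only measured step, a 29-fold lower number from compound 1 to compound 2 (1.46 log units; beyond the scatter), concerns configuration alone and not this side group, so it offers no direct guide to the exchange. The counted donors and acceptors are unchanged by the swap, while the group entering is shorter than the one leaving. For the measured compounds named here, with no measured step on the group itself, the expected step of a 2.4-fold higher number from compound 2 to compound 3 (0.38 log units; beyond the scatter) is a modest rise in number, close to the scatter. For compound 3 the estimate in this assay is 12 nM, with a range from 3 nM to 50 nM.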

Compound 3, half-maximal inhibitory concentration: 43 nM
Estimate against measurement, compound 3: 3.6-fold (0.55 log units) below; low and high end bracket the measured number.
By their numbers in this assay, from the lowest: compound 2; then compound 3; then compound 1.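

With configuration held fixed, the exchange of (2-methoxyethyl)carbamoyl for methylsulfamoyl in this assay gives an 8.6-fold higher number from compound 2 to compound 3 (0.93 log units; beyond the scatter), so this saturated ring carbon responds to the side group as well as to configuration. The counted hydrogen-bond donors and acceptors are the same in the leaving and entering groups, so these counts do not account for the step, and the differences that remain are the smaller heavy-atom count of the entering group, the sulfur it brings and the loss of the methoxyethyl chain. No measured finding available for the series bears on the reason for this step.

The compounds shown do not separate the shortening of the chain from the replacement of the carbonyl by the sulfur-bearing group, a question that methylcarbamoyl on this ring carbon would address directly. Also open, going by these compounds, are the size of the configuration step with methylsulfamoyl in place and the response of this position to an amine, a carboxylic acid or a longer chain on the sulfamoyl nitrogen.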